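The compounds below may be only part of what the source reports. "The series", "measured", "known", "first", "only" and "open" are said of these compounds alone.

Two compounds of this series have numbers in an assay on isolated protein for displacement of a labelled ligand from melanin-concentrating hormone receptor 1 (Rattus norvegicus); a higher number here means a weaker inhibitor, a lower number a stronger inhibitor. Compound 1 `CC(=O)Nc1cccc(C2CCN(CCCC(=O)c3ccc(Cl)cc3)CC2)c1` gives 70 nM. Compound 2 `CC(C)C(=O)Nc1cccc(C2CCN(Cc3cccc(Oc4ccc(Cl)cc4)c3)CC2)c1` gives 23 nM, the lower of the two numbers, with compound 1 as its nearest neighbour at a gap beyond the scatter. Compound 3 `CC(C)C(=O)Nc1cccc(C2CCN(Cc3cccc(Oc4cc(Cl)cc(Cl)c4)c3)CC2)c1` is not yet measured; it differs from compound 2 by 3,5-dichlorophenyl in place of 4-chlorophenyl on an oxygen on an aromatic ring. Among the compounds with values here, no measured pair shows this change, so its effect cannot be read from the data. A small step is expected, a 1.1-fold higher number from compound 2 to compound 3 (0.04 log units; within the scatter), in either direction or none beyond the scatter. Compound 3 is estimated at 25 nM in this assay, within 8 nM to 80 nM.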

Compound 3, inhibition constant: 140 nM
For compound 3 the middle estimate is 5.6-fold (0.75 log units) below the measured one; the whole stated range lies below it.
By their numbers in this assay, from the lowest: compound 2; then compounds 1 and 3 (each within the scatter of the next).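

In this assay, within the data shown here, the change to 3,5-dichlorophenyl in place of 4-chlorophenyl on an oxygen on an aromatic ring gives a 6.1-fold higher number from compound 2 to compound 3 (0.78 log units; beyond the scatter) and is the first step that can be read. This position is therefore sensitive to the chlorine pattern on the ring, and the added chlorine does not keep the number of compound 2. Nothing available explains the step.

Still open, on these data alone, is how an unsubstituted phenyl, or a phenyl carrying a methoxy or trifluoromethyl group, would behave on this oxygen. As far as these compounds go, it is also open whether the same change has a similar effect with other groups elsewhere on the shared core.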